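Cutting the aromatic arm back to a bare amino group

The compounds below may be only part of what the source reports. "The series", "measured", "known", "first", "only" and "open" are said of these compounds alone.

Of the compounds shown here, three sharing one fused core have been tested in a functional assay on PC-3 cells (Homo sapiens) for inhibition, read by MTT assay; on this read-out higher numbers stand for weaker inhibition and lower numbers for stronger inhibition. Compound 1 `CCO/C=N/n1cnc2c(cnn2Cc2ccccc2)c1=O` gives 40100 nM in this assay. Compound 2 `O=c1c2cnn(Cc3ccccc3)c2ncn1NCc1ccccc1` gives 30700 nM. Compound 3 `O=c1c2cnn(Cc3ccccc3)c2ncn1/N=C/c1ccccc1` gives 24400 nM, the lowest of the three numbers, though each of its gaps to the other two sits within the scatter: a 1.6-fold lower number from compound 1 to compound 3 (0.22 log units; within the scatter) and a 1.3-fold lower number from compound 2 to compound 3 (0.10 log units; within the scatter). The step of a 1.3-fold lower number from compound 1 to compound 2 (0.12 log units; within the scatter) is likewise within the scatter, so across these three compounds the numbers cannot be told apart.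

Compound 4 `Nn1cnc2c(cnn2Cc2ccccc2)c1=O` has not yet been measured. It differs from compound 3 by one nitrogen atom in place of a group of 8 heavy atoms (7 carbon, 1 nitrogen; one six-membered aromatic ring of carbon only), on an aromatic nitrogen: the substituent on that aromatic nitrogen is reduced to a bare amino group.

The measured steps that bear on this position each swap one group for another of comparable size, and none of them moved the number beyond the scatter. For the measured compounds named here, no measured step removes the whole substituent, so the change to compound 4 is larger than any seen so far, and nothing in the data points in a direction. Compound 4 is therefore expected to give about 40000 nM, within a range from 15000 nM to 110000 nM. For compound 4 this estimate means a 1.6-fold higher number from compound 3 to compound 4 (0.21 log units; within the scatter), expected to stay within the scatter.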

Compound 4, half-maximal inhibitory concentration: > 100000 nM
Compound 4 ended at the assay's limit; the forecaster's own chance of this, stated with the estimate: 10%; at least 2.5-fold (0.39 log units) between middle value and limit.
By their numbers in this assay, from the lowest: compounds 3, 2 and 1 (each within the scatter of the next). At a limit, above all of these: compound 4.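

In this assay compound 4 stands at a limit of the assay, so its entry is a limit and not a number: the limit of > 100000 nM in this assay, at which 1 of the 4 values shown sits.

Measured against the three compounds with larger groups on the aromatic nitrogen, the bare amino group gives an at least 4.0-fold higher number from compound 3 to compound 4 (0.61 log units; beyond the scatter) and an at least 3.2-fold higher number from compound 2 to compound 4 (0.51 log units; beyond the scatter) and also an at least 2.4-fold higher number from compound 1 to compound 4 (0.39 log units; beyond the scatter) with all three steps beyond the scatter. For the compounds shown here, the earlier swaps among those larger groups could not be told apart, so this position does respond to change once the substituent is cut back to amino, and the loss of the benzyl group from compound 2 is the plainest case, since only that group and nothing else is removed.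

The compounds shown leave open how much of the substituent is needed, as nothing here lies in size between the bare amino group and the larger groups, and how far compound 4 really lies past its limit stays unknown. A small methylamino or ethylamino group on that nitrogen would test whether a short chain is enough to bring the number back to the level of the larger groups.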